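The source may hold more compounds than are shown below. What is called first, only, known or untested is meant among the compounds shown, and "the series" means these compounds.

Of the compounds shown here, three sharing a core have been tested in an ADME assay on HepG2 cells (Homo sapiens) for cytotoxicity, read by MTT assay, with a stated time of 72 h; a lower number here means that less compound is tolerated, a higher number that more compound is tolerated. Compound 1 `Oc1ccccc1/C=N/c1sc2c(c1-c1nc3ccccc3s1)CCC2` gives 156 ug/mL in this assay. Compound 2 `C(=C/c1ccccc1)\C=N\c1sc2c(c1-c1nc3ccccc3s1)CCC2` gives 215 ug/mL in this assay, and compound 3 `C(=C/c1ccccc1)\C=N\c1sc2c(c1-c1nc3ccccc3s1)CCCC2` gives 467 ug/mL in this assay, the highest of the three numbers, with its gap to compound 2 and its gap to compound 1 both beyond the scatter. Compound 4 `Oc1ccccc1/C=N/c1sc2c(c1-c1nc3ccccc3s1)CCCC2` has not yet been measured in this assay.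

Compound 1 and compound 2 differ in one place: 2-hydroxyphenyl in place of 2-phenylethenyl on a carbon with a double bond to nitrogen. That change gave a 1.4-fold lower number from compound 2 to compound 1 (0.14 log units; within the scatter), a step that lies within the scatter, so the two numbers cannot be told apart with confidence. The difference between the core of compound 2 and the core of compound 3 is not broken down here. Compound 4 stands to compound 3 as compound 1 stands to compound 2: 2-hydroxyphenyl in place of 2-phenylethenyl on a carbon with a double bond to nitrogen. The place is described in the same words in both cases, so this is the same change made on a different core. Among the compounds with values here, the step expected here, a 1.4-fold lower number from compound 3 to compound 4 (0.14 log units; within the scatter), is close to the earlier one because the only measured example of this change is a 1.4-fold lower number from compound 2 to compound 1 (0.14 log units; within the scatter). On that basis compound 4 is estimated to give 340 ug/mL in this assay, with a likely range from 180 ug/mL to 650 ug/mL.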

Compound 4, half-maximal cytotoxic concentration: 114 ug/mL
Compound 4: middle estimate off by 3.0-fold (0.47 log units), on the high side; the whole stated range lies above it.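

In this assay, replacing 2-phenylethenyl with 2-hydroxyphenyl on a carbon with a double bond to nitrogen gave a 4.1-fold lower number from compound 3 to compound 4 (0.61 log units; beyond the scatter). Within the data shown here, the same change therefore does not have one fixed size, and the step seen on one core did not carry over to the other, as the two steps differ by more than repeated measurements would explain: the same change on two cores in this assay, a 1.4-fold lower number (0.14 log units; within the scatter) from compound 2 to compound 1 and a 4.1-fold lower number (0.61 log units; beyond the scatter) from compound 3 to compound 4, 3.0-fold (0.47 log units) apart, beyond the scatter of two such steps This shows that the size of the step depends on the core in this one comparison, but with only two cores it does not show why, what the change would do on a third core, or whether the two steps share a direction, since the first lies within the scatter.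

The compounds shown leave open which part of the change matters, the hydroxyl group or the loss of the double bond outside the aromatic ring, and a plain phenyl group in the same place would help to separate the two. Also open, from the compounds shown here alone, is how other groups there, such as a methoxyphenyl or an aminophenyl, would behave on these two cores.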